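Chain-end swaps on the shared core: toward compound 4

The compounds below may be only part of what the source reports. "The series", "measured", "known", "first", "only" and "open" are said of these compounds alone.

Measured in a functional assay on K562 cells (Homo sapiens) for antiproliferative activity, read by MTT assay, with a stated time of 48 h; on this read-out lower numbers stand for stronger inhibition and higher numbers for weaker inhibition:
compound 1 `CN(C)CCCn1nc(C2=C(c3cn(C)c4ccccc34)C(=O)N(c3ccccc3)C2=O)c2cccnc21` gives 1700 nM
compound 2 `Cn1cc(C2=C(c3nn(CCCCn4ccnc4)c4ncccc34)C(=O)N(c3ccccc3)C2=O)c2ccccc21` gives 5030 nM
compound 3 `Cn1cc(C2=C(c3nn(CCCN4CCCCC4)c4ncccc34)C(=O)N(c3ccccc3)C2=O)c2ccccc21` gives 3790 nM

Compound 3 stands second highest of the three numbers in this assay: it sits within the scatter of compound 2, as a 1.3-fold lower number from compound 2 to compound 3 (0.12 log units; within the scatter) shows, and beyond the scatter from compound 1, as a 2.2-fold higher number from compound 1 to compound 3 (0.35 log units; beyond the scatter) shows. Compound 4 `Cn1cc(C2=C(c3nn(CCCn4cncn4)c4ncccc34)C(=O)N(c3ccccc3)C2=O)c2ccccc21` differs from compound 3 by 1H-1,2,4-triazol-1-yl in place of piperidin-1-yl on a saturated chain carbon, three bonds along the chain from an aromatic nitrogen. Among the measured compounds shown here, the steps that bear on this are a 3.0-fold higher number from compound 1 to compound 2 (0.47 log units; beyond the scatter) and a 2.2-fold higher number from compound 1 to compound 3 (0.35 log units; beyond the scatter), both modest rises away from the dimethylamino parent, while a 1.3-fold lower number from compound 2 to compound 3 (0.12 log units; within the scatter) between the two ring-bearing chains is within the scatter. A ring-for-ring exchange is therefore expected to give no step beyond the scatter, roughly a 1.2-fold higher number from compound 3 to compound 4 (0.07 log units; within the scatter). Compound 4 is estimated at 4500 nM in this assay, with a range of 2000 nM to 10000 nM.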

Compound 4, half-maximal inhibitory concentration: > 100000 nM
Compound 4 ended at the assay's limit; the forecaster's own chance of this, stated with the estimate: 5%; at least 22-fold (1.34 log units) between middle value and limit.
By their numbers in this assay, from the lowest: compound 1; then compounds 3 and 2 (each within the scatter of the next). At a limit, above all of these: compound 4.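

Compound 4 stands at a limit of the assay, not at a number: the limit of > 100000 nM in this assay, at which 1 of the 4 values shown sits. Read against the other chain ends, the change is large each time: an at least 26-fold higher number from compound 3 to compound 4 (1.42 log units; beyond the scatter), an at least 19-fold higher number from compound 2 to compound 4 (1.29 log units; beyond the scatter) and an at least 58-fold higher number from compound 1 to compound 4 (1.76 log units; beyond the scatter). This place therefore accepts dimethylamino, piperidin-1-yl and (1H-imidazol-1-yl)methyl with modest steps or none beyond the scatter, so a ring at the chain end does not by itself give the result seen with 1H-1,2,4-triazol-1-yl.

Still open, as far as these compounds go, is how a morpholin-4-yl or 1H-pyrazol-1-yl group would read at this place. Also open, from the compounds shown here alone, is whether a longer chain carrying 1H-1,2,4-triazol-1-yl would come back within the assay's range.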